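Swapping Fluoro for Bromo in a Cytotoxicity Screen

The source may report more compounds than this note shows. Statements on the series, on what has been measured and on what is new or still open speak of the compounds shown alone.

Four compounds share one core, differing only in the group on the ring-bound nitrogen and in the halogen on the aromatic carbon. In a toxicity assay on MCF-10A cells (Homo sapiens) for cytotoxicity, read by MTT assay, with a stated time of 48 h (on this read-out higher numbers stand for weaker inhibition and lower numbers for stronger inhibition), compound 1 `CCn1c(/C=C2/C(=O)Nc3ccc(Br)cc32)nc2ccccc21` gives "not determined" (no result reported) and compound 2 `Cn1c(/C=C2/C(=O)Nc3ccc(Br)cc32)nc2ccccc21` gives "not determined" (no result reported), so neither contributes a number to compare against.

Compound 3 `CC(C)n1c(/C=C2/C(=O)Nc3ccc(F)cc32)nc2ccccc21` in this assay gives > 100000 nM, and this is a limit of the assay rather than a measured number. Among the three entries shown, compound 3 therefore stands as the only one with any reading at all, and that reading is a limit; no single numbers sit beside it, and no step between measured compounds can be drawn.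

Compound 4 `CC(C)n1c(/C=C2/C(=O)Nc3ccc(Br)cc32)nc2ccccc21` differs from compound 3 by bromo in place of fluoro on an aromatic carbon. Among the measured compounds shown here, with no measured step to lean on, the expected step in this assay is none beyond the scatter; the step from compound 3 to compound 4 is estimated as a number no higher from compound 3 to compound 4 (the limit leaves the size open). Because compound 3 sits at the limit of > 100000 nM in this assay, at which 1 of the 3 values shown sits, compound 4 is most likely to return a limit as well. Compound 4 is expected to give 100000 nM, within a range from 30000 nM to 300000 nM.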

Compound 4, half-maximal inhibitory concentration: 56900 nM
For compound 4 the middle estimate is 1.8-fold (0.24 log units) above the measured one; the range from low to high includes it.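

Among the compounds shown, compound 4 is the only one with a single number in this assay, which gives this aromatic carbon its first reading that is not a limit. Putting bromo in place of fluoro here gives an at least 1.7-fold lower number from compound 3 to compound 4 (0.24 log units; that floor lies within the scatter), so the change can be described only by a floor, and that floor does not rise beyond the ordinary spread of repeated measurements. The true size of the step remains unknown because compound 3 has only a limit and not a number: the limit of > 100000 nM in this assay, at which 1 of the 4 values shown sits.

The steps involving compound 1 and compound 2 cannot be read, so these compounds say nothing yet about how the group on the ring-bound nitrogen matters alongside this halogen. On these data alone, it also remains open whether chloro, a nitrile or an amine on this same aromatic carbon would give a number that stands clearly apart from compound 4, and whether any such change would produce a step beyond the scatter.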